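Replacing methyl with phenylsulfonyl on a ring nitrogen

The compounds below may be only part of what the source reports. "The series", "measured", "known", "first", "only" and "open" are said of these compounds alone.

In a functional assay on SK-OV-3 cells (Homo sapiens) for cytotoxicity, read by MTT assay, with a stated time of 3 days (on this read-out lower numbers stand for stronger inhibition and higher numbers for weaker inhibition), compound 1 `N#Cc1c(O)nc(SCc2nc3ccccc3[nH]2)nc1-c1ccccc1` gives 2.55 nM and compound 2 `N#Cc1c(-c2ccccc2)nc(SCc2nc3ccccc3[nH]2)nc1N1CCNCC1` gives 2.63 nM, with a 1.0-fold higher number from compound 1 to compound 2 (0.01 log units; within the scatter). Compound 3 `CN1CCN(c2nc(SCc3nc4ccccc4[nH]3)nc(-c3ccccc3)c2C#N)CC1` has the highest number of the three at 1600 nM, with a 630-fold higher number from compound 1 to compound 3 (2.80 log units; beyond the scatter).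

Compound 4 `N#Cc1c(-c2ccccc2)nc(SCc2nc3ccccc3[nH]2)nc1N1CCN(S(=O)(=O)c2ccccc2)CC1` carries phenylsulfonyl in place of the methyl of compound 3, on an amine nitrogen in a ring: phenylsulfonyl in place of methyl on an amine nitrogen in a ring. The measured step that bears most directly on this change is the one at the same nitrogen, methyl in place of hydrogen, with a 610-fold higher number from compound 2 to compound 3 (2.78 log units; beyond the scatter). It shows that a change at this nitrogen can produce a large step in this assay. For the measured compounds named here, no measured compound has phenylsulfonyl there, so the direction remains uncertain. Compound 3 stands at the top of the measured numbers, so a step toward a lower number is the more likely outcome, and the expected step is an 8.0-fold lower number from compound 3 to compound 4 (0.90 log units; beyond the scatter). For compound 4 the estimated value is 200 nM, with an expected range of 5 nM to 5000 nM.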

Compound 4, half-maximal inhibitory concentration: 2.77 nM
The estimate for compound 4 lay 72-fold (1.86 log units) above the measured number, and the stated range ends above it.
By their numbers in this assay, from the lowest: compounds 1, 2 and 4 (each within the scatter of the next); then compound 3.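

In this assay the step of a 580-fold lower number from compound 3 to compound 4 (2.76 log units; beyond the scatter) shows that the high number of compound 3 does not extend to every substituent on this amine nitrogen in a ring, since phenylsulfonyl, with its 9 heavy atoms and aromatic ring, goes with a low number. The step of a 1.1-fold higher number from compound 2 to compound 4 (0.02 log units; within the scatter) places phenylsulfonyl level with hydrogen at this nitrogen, so among the three groups shown there, only methyl stands apart. Nothing shown here accounts for why methyl differs from both hydrogen and phenylsulfonyl.

As far as these compounds go, it remains open whether the high number belongs to methyl alone or also to a longer chain such as ethyl or propyl on the same nitrogen. The compounds shown also leave open how an acetyl or a benzyl group would read there.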